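From Cyclohexyl to an Aromatic Ring: A Half-Life Estimate

This account rests on a few compounds, and the source may have more. Where it says the series, first, only, none or still open, it means among the compounds named here.

Of the compounds shown here, three with a shared core have so far been tested in an ADME assay on microsomes from liver (Rattus norvegicus) for metabolic stability; on this read-out lower numbers stand for a shorter-lived compound and higher numbers for a longer-lived compound. Compound 1 (`CC#C[C@@H](Cc1nnn[nH]1)c1ccc(OCc2ccc3scc(C4CCCCC4)c3c2)cc1`) gives 0.767 h. Compound 3 (`CC#C[C@@H](Cc1nnn[nH]1)c1ccc(OCc2ccc3sc(I)c(-c4ccccc4C)c3c2)cc1`) gives 0.483 h, which lies within the scatter of compound 1, so repeat measurements might not tell the two apart. Compound 2 (`CC#C[C@@H](Cc1nnn[nH]1)c1ccc(OCc2cc(F)c3scc(-c4ccc(OC)cc4C)c3c2)cc1`) gives 0.333 h, and here compound 1 stands above it by a gap beyond the scatter.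

Compound 4 (`CC#C[C@@H](Cc1nnn[nH]1)c1ccc(OCc2ccc3scc(-c4ccccc4C(F)(F)F)c3c2)cc1`) has not been measured yet. It keeps the core of compound 1 and changes one group: 2-(trifluoromethyl)phenyl in place of cyclohexyl on an aromatic carbon, two ring bonds from the ring sulfur (2-(trifluoromethyl)phenyl in place of cyclohexyl on an aromatic carbon).

Among the measured compounds shown here, no measured pair isolates this swap, so any forecast is rough. Compound 2 at 0.333 h and compound 3 at 0.483 h also carry an aromatic ring at that place, although both differ from compound 1 elsewhere too. A small downward move is therefore expected, probably within the scatter. The estimated change is a 1.4-fold lower number from compound 1 to compound 4 (0.14 log units; within the scatter). In this assay, compound 4 is expected at 0.55 h, with an estimated range from 0.28 h to 1.1 h.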

Compound 4, half-life: 0.167 h
The estimate for compound 4 lay 3.3-fold (0.52 log units) above the measured number; the whole stated range lies above it.
By their numbers in this assay, from the lowest: compounds 4, 2, 3 and 1 (each within the scatter of the next, the first and the last beyond it).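

In this assay, putting 2-(trifluoromethyl)phenyl in place of cyclohexyl on an aromatic carbon, two ring bonds from the ring sulfur, gives a 4.6-fold lower number from compound 1 to compound 4 (0.66 log units; beyond the scatter). Among the compounds shown here, this is the first change that can be read at a single place with the rest of the structure held fixed, and it shows that the group at this position can by itself move the half-life by more than the usual scatter of repeated measurements. Nothing available here measures what lies behind this step, so the result records its direction and size but not its explanation.

The swap alters two things at once, the ring type and the trifluoromethyl group, so this one step cannot show how much each contributes, and a plain phenyl group at the same position would be needed to separate them. Going by these compounds, it also remains open how other groups at this place would behave, such as a small open chain like tert-butyl or a ring carrying an amine like piperidine, so one step gives no trend across the position.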